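The source may hold more compounds than are shown below. What is called first, only, known or untested is meant among the compounds shown, and "the series" means these compounds.

Among the compounds with values here, of the two numbers so far in a functional assay on HepG2 cells (Homo sapiens) for antiproliferative activity, read by CCK-8 assay, with a stated time of 72 h (on this read-out higher numbers stand for weaker inhibition and lower numbers for stronger inhibition), compound 2 `COc1cc(OC)cc(C(=O)Nc2cccc(-c3oc4cc(-c5ccc(F)cc5)ccc4c(=O)c3O)c2)c1` gives 23500 nM and compound 1 `O=C(Nc1cccc(-c2oc3cc(-c4ccc(F)cc4)ccc3c(=O)c2O)c1)c1ccc(C(F)(F)F)cc1` gives 42700 nM; the gap between them lies within the scatter, so neither stands apart. Compound 3 `O=C(Nc1cccc(-c2oc3cc(-c4ccc(F)cc4)ccc3c(=O)c2O)c1)c1cc(F)cc(F)c1` differs from compound 2 by 3,5-difluorophenyl in place of 3,5-dimethoxyphenyl on a carbonyl carbon. Within the data shown here, the one step that bears on this, a 1.8-fold lower number from compound 1 to compound 2 (0.26 log units; within the scatter), also exchanged the group on that carbonyl carbon and stayed within the scatter. A similar outcome is therefore expected here, a 1.3-fold higher number from compound 2 to compound 3 (0.11 log units; within the scatter), with no shift beyond the scatter in this assay. Compound 3 is estimated at 30000 nM, between 10000 nM and 90000 nM.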

Compound 3, half-maximal inhibitory concentration: 4960 nM
Compound 3: the middle estimate sits 6.0-fold (0.78 log units) above what was measured; the whole stated range lies above it.
By their numbers in this assay, from the lowest: compound 3; then compounds 2 and 1 (each within the scatter of the next).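

The group on this carbonyl carbon can change the result in this assay: 3,5-difluorophenyl in place of 3,5-dimethoxyphenyl gives a 4.7-fold lower number from compound 2 to compound 3 (0.68 log units; beyond the scatter), and in place of 4-(trifluoromethyl)phenyl it gives an 8.6-fold lower number from compound 1 to compound 3 (0.93 log units; beyond the scatter). Both steps lie beyond the scatter, though both are modest, so exchanges at this position are not all equivalent, as the earlier pair alone could not show. Nothing available here explains the difference.

Going by these compounds, whether 3,5-dichlorophenyl, a pyridine ring or a phenyl ring carrying a single fluorine would keep this gain remains open. So does whether the gain extends to other cell lines.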